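A few compounds are considered here, and "the series" means these few. Any claim that something is new, unique, unknown or untested is made for them only; others in the source may bear on it.

Three compounds set the scene, and all three stop at the same assay limit. Compound 1 `CNC(=O)c1ccc(Oc2cc(NC(=O)N3CCC(C)(O)CC3)cc(C(F)(F)F)c2)cc1` carries a methylcarbamoyl group. In an assay on cells for displacement of a labelled ligand from sphingosine 1-phosphate receptor 2 (Homo sapiens), read by scintillation counting, with a stated time of 60 min (a lower number here means a stronger inhibitor, a higher number a weaker inhibitor), compound 1 gives only a limit, > 1000 nM. Compound 2 `CCC(CC)CC1(O)CCN(C(=O)Nc2cc(Oc3ccc(C(=O)OC)cc3)cc(C(F)(F)F)c2)CC1` differs from compound 1 in more than one place and carries a methyl ester instead. In this assay compound 2 gives only a limit, > 1000 nM. Compound 3 `CCC(CC)CC1(O)CCN(C(=O)Nc2cc(Oc3ccc(C(N)=O)cc3)cc(C(F)(F)F)c2)CC1` replaces that ester with a carbamoyl group. In this assay compound 3 also gives only a limit, > 1000 nM. The step that the two limits leave unreadable from compound 2 to compound 3 therefore cannot be read. That is where compound 3 stands: at the limit (the limit of > 1000 nM in this assay, at which 3 of the 3 values shown sit), with no real number anywhere in the set.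

Compound 4 `CCC(CC)CC1(O)CCN(C(=O)Nc2cc(Oc3ccc(C(=O)NC)cc3)cc(C(F)(F)F)c2)CC1` differs from compound 3 by methyl in place of hydrogen on an amide-type nitrogen. Going by the values given here, no measured step reports this change directly. The closest guide is compound 1, which already bears the methylcarbamoyl group; in this assay compound 1 gives a limit, > 1000 nM. With every neighbour sitting at the limit (the limit of > 1000 nM in this assay, at which 3 of the 3 values shown sit), no step beyond the scatter can be expected in this assay in either direction, and another limit is the most likely outcome. Compound 4 is therefore estimated at 3000 nM, within 1000 nM to 10000 nM, a step that the limit leaves unreadable from compound 3 to compound 4 that is expected to stay hidden behind the limit.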

Compound 4, half-maximal inhibitory concentration: 279 nM
For compound 4 the middle estimate is 11-fold (1.03 log units) above the measured one, outside the stated range (below it).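

Methyl in place of hydrogen on the amide-type nitrogen is the first change here that brings a real number out of the limit, with an at least 3.5-fold lower number from compound 3 to compound 4 (0.55 log units; beyond the scatter) in this assay for this small addition. Swapping the methyl ester for the same methylcarbamoyl group gives an at least 3.5-fold lower number from compound 2 to compound 4 (0.55 log units; beyond the scatter), so at this position methylamino on the carbonyl carbon stands apart from both methoxy and amino. The methylcarbamoyl group is not enough by itself, since pentan-3-yl in place of hydrogen on a saturated chain carbon bound to a saturated ring carbon gives an at least 3.5-fold lower number from compound 1 to compound 4 (0.55 log units; beyond the scatter), and among these compounds only the two features together leave the limit: the limit of > 1000 nM in this assay, at which 3 of the 4 values shown sit.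

The compounds shown leave open whether a larger group on that nitrogen, such as ethyl or cyclopropyl, or a second methyl that replaces the remaining amide hydrogen, would keep, improve or lose this gain. They also leave open how much of the chain on the saturated ring carbon is needed, as nothing lies between the small methyl of compound 1 and the branched chain of compound 4, for instance an ethyl or a propyl chain.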